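The source may hold more compounds than are shown below. What is called first, only, known or untested is meant among the compounds shown, and "the series" means these compounds.

Measured so far in a functional assay on HepG2 cells (Homo sapiens) for antiproliferative activity, read by XTT assay, with a stated time of 72 h; on this read-out lower numbers stand for stronger inhibition and higher numbers for weaker inhibition:
- compound 1 `Nc1nc(N)c2c(-c3ccsc3)cn([C@@H]3O[C@H](CO)[C@@H](O)[C@H]3O)c2n1`: > 20000 nM
- compound 2 `O=c1[nH]cnc2c1c(-c1ccoc1)cn2[C@@H]1O[C@H](CO)[C@@H](O)[C@H]1O`: 12100 nM
- compound 3 `CSc1ncnc2c1c(-c1ccccc1)cn2[C@@H]1O[C@H](CO)[C@@H](O)[C@H]1O`: > 20000 nM

The value of compound 1 is a limit of the assay and not a number. The value of compound 3 is likewise a limit. Among the compounds with values here, compound 2 therefore carries the only number in the set, the two others sitting at the limit of > 20000 nM in this assay, at which 2 of the 3 values shown sit. Within the data shown here, no pair of these three differs in one place, so no measured step is available.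

Compound 4 `O=c1[nH]cnc2c1c(-c1cccs1)cn2[C@@H]1O[C@H](CO)[C@@H](O)[C@H]1O` is to be measured in this assay. It differs from compound 2 in one place: thiophen-2-yl in place of furan-3-yl on an aromatic carbon. The change exchanges one five-membered aromatic ring with 1 hetero atom for another of the same size. With nothing measured to go on, the expected step from compound 2 to compound 4, a 1.0-fold lower number from compound 2 to compound 4 (0.00 log units; within the scatter), is none beyond the scatter. Compound 4 is thus estimated at 12000 nM, within 5000 nM to 20000 nM.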

Compound 4, half-maximal inhibitory concentration: > 20000 nM
Compound 4 ended at the assay's limit; the forecaster's own chance of this, stated with the estimate: 35%; at least 1.6-fold (0.22 log units) between middle value and limit.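

The aromatic carbon bearing furan-3-yl now has its first measured step in this assay: an at least 1.6-fold higher number from compound 2 to compound 4 (0.21 log units; that floor lies within the scatter). Compound 4 gives > 20000 nM, which is a limit of the assay and not a number. The floor of this step stays within the scatter, so the exchange of these two five-membered aromatic rings is not shown to weaken inhibition, and compound 4 joins the compounds at the limit: the limit of > 20000 nM in this assay, at which 3 of the 4 values shown sit.

As far as these compounds go, the true size of the step remains open. Also open, from the compounds shown here alone, is how a methyl group or an amine on this carbon of the core of compound 2 would read.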